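Ring Growth on the Carbonyl: Cyclobutyl to Cyclopentyl

The source may hold more compounds than are shown below. What is called first, only, known or untested is meant among the compounds shown, and "the series" means these compounds.

Of the compounds shown here, three of one shared core have been measured in an assay on isolated protein for inhibition of Nitric oxide synthase, inducible (Homo sapiens), read by scintillation counting, with a stated time of 30 min, tested at 50 uM; a lower number here means less inhibition, a higher number more inhibition at the concentration tested (going by the name of the read-out). Compound 1 `COc1ccc(N)c(C2=NN(C(C)=O)C(C)(C)S2)c1` gives 77.1%; compound 2 `COc1ccc(N)c(C2=NN(C(=O)C3CC3)C(C)(C)S2)c1` gives 90.1%; compound 3 `COc1ccc(N)c(C2=NN(C(=O)C3CCC3)C(C)(C)S2)c1` gives 57.8%. Compound 3 stands lowest of the three: its nearest neighbour on the numbers is compound 1, and compound 2 lies furthest above it. The measured steps are a number 13 percentage points higher from compound 1 to compound 2 (beyond the scatter), a number 19.3 percentage points lower from compound 1 to compound 3 (beyond the scatter) and a number 32.3 percentage points lower from compound 2 to compound 3 (beyond the scatter). Compound 4 `COc1ccc(N)c(C2=NN(C(=O)C3CCCC3)C(C)(C)S2)c1` differs from compound 3 in one place: cyclopentyl in place of cyclobutyl on a carbonyl carbon. The step that bears on it most is the one in which the ring on the carbonyl carbon grew by one carbon, a number 32.3 percentage points lower from compound 2 to compound 3 (beyond the scatter), a large fall; the step of a number 19.3 percentage points lower from compound 1 to compound 3 (beyond the scatter) likewise points downward for the cyclobutyl. The step from methyl to cyclopropyl went the other way, so the direction is not uniform across the three, but with one more ring carbon the expected step is a number 9.8 percentage points lower from compound 3 to compound 4 (within the scatter). Compound 4 is therefore estimated at 48%, with a range from 25% to 72%.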

Compound 4, a percentage reported as inhibition, at one concentration (the size of the read-out at that concentration, not a potency): 65%
For compound 4 the middle estimate is 17 percentage points below the measured one, within the range that was stated.
By their numbers in this assay, from the lowest: compounds 3 and 4 (each within the scatter of the next); then compound 1; then compound 2.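

In this assay the ring on the carbonyl carbon grows from cyclobutyl to cyclopentyl with a number 7.2 percentage points higher from compound 3 to compound 4 (within the scatter) and so the large fall on leaving cyclopropyl is not extended by this further ring carbon. The cyclopentyl compound also shows a number 25.1 percentage points lower from compound 2 to compound 4 (beyond the scatter) and a number 12.1 percentage points lower from compound 1 to compound 4 (beyond the scatter) so that among the three rings shown at this position only cyclopropyl stands above methyl. Nothing measured here gives a reason for these differences.

The compounds shown leave open whether cyclohexyl would stay at this level, and whether isopropyl, an open chain with a branch, would match cyclopropyl or fall with the larger rings. As far as these compounds go, they also give the read-out at one concentration only, so how the four compare in potency remains open.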